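The source may hold more compounds than are shown below. What is called first, only, known or untested is meant among the compounds shown, and "the series" means these compounds.

The compounds share one core, and their potency is read in a functional assay on MKN-74 cells (Homo sapiens) for antiproliferative activity, with a stated time of 24 h; on this read-out lower numbers stand for stronger inhibition and higher numbers for weaker inhibition. Compound 1, `NC(=O)c1c(NC(=O)c2ccccc2Cl)sc2c1CCN(Cc1ccccc1F)C2`, gives 12900 nM. Compound 2, `NC(=O)c1c(NC(=O)c2ccccc2Cl)sc2c1CCN(Cc1c(Cl)cccc1Cl)C2`, gives 4740 nM. Compound 3, `NC(=O)c1c(NC(=O)c2ccccc2)sc2c1CCN(C(=S)Nc1ccccc1Cl)C2`, gives 11800 nM. On these three numbers compound 3 stands second highest: its number and that of compound 1 lie within the scatter of each other, while compound 2 sits at a lower number, beyond the scatter.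

Compound 4 is `Cc1ccc(C(=O)Nc2sc3c(c2C(N)=O)CCN(C(=S)Nc2ccccc2Cl)C3)cc1`, not yet measured. It differs from compound 3 in one place: methyl in place of hydrogen on an aromatic carbon.

Within the data shown here, only one measured step exists among the three compounds, a 2.7-fold lower number from compound 1 to compound 2 (0.43 log units; beyond the scatter), and it concerns a different place in the molecule, the saturated chain carbon bound to the amine nitrogen in the ring, not the benzamido part. Among the measured compounds shown here, no measured pair shows what a methyl in place of hydrogen on the aromatic ring of the benzamido group does. The expectation for compound 4 therefore rests on compound 3 alone, and the step of a 1.2-fold lower number from compound 3 to compound 4 (0.07 log units; within the scatter) is expected to stay within the scatter. Compound 4 is estimated at 10000 nM in this assay, with a range from 4000 nM to 30000 nM.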

Compound 4, half-maximal inhibitory concentration: 11300 nM
Estimate against measurement, compound 4: 1.1-fold (0.05 log units) below; low and high end bracket the measured number.
By their numbers in this assay, from the lowest: compound 2; then compounds 4, 3 and 1 (each within the scatter of the next).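

In this assay, among these compounds, the step of a 1.0-fold lower number from compound 3 to compound 4 (0.02 log units; within the scatter) is the first measured reading at the benzamido part of these molecules, and on it phenyl and 4-methylphenyl cannot be told apart. Among the compounds shown here, the only step measured before lay at the saturated chain carbon bound to the amine nitrogen in the ring, so this pair adds that one methyl on an aromatic carbon, para to a large group, does not move the number beyond the scatter, at least with the substituent that compound 3 and compound 4 share on that nitrogen. Nothing measured here accounts for this outcome.

On these data alone, whether a larger or differently built group at the same place, such as a methoxy group, an amine or a carboxylic acid, would also leave the number within the scatter remains open. As far as these compounds go, it is equally open whether a methyl on another carbon of this ring would behave the same way, or whether this methyl would do so in a compound carrying the 2,6-dichlorophenyl group of compound 2.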